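The source may hold more compounds than are shown below. What is called first, only, known or untested is meant among the compounds shown, and "the series" means these compounds.

In a functional assay on CLL cells (Homo sapiens) for cytotoxicity, read by MTT assay, with a stated time of 48 h (on this read-out lower numbers stand for an effect already at smaller amounts and higher numbers for an effect only at larger amounts of compound), three compounds sharing a core have been measured. Compound 1 (`C=C(CC)C(=O)c1ccc(OCC(=O)NCC(=O)O)c(Cl)c1Cl`) reaches only a limit of the assay, > 25000 nM. Compound 2 (`C=C(CC)C(=O)c1ccc(OCC(=O)NC(CS)C(=O)OCC)c(Cl)c1Cl`) gives 4800 nM. Compound 3 (`C=C(CC)C(=O)c1ccc(OCC(=O)Nc2ccc(/C=C/C(=O)OCC)cc2)c(Cl)c1Cl`) gives 1700 nM, the lower of the two actual numbers, and its gap to compound 2 lies beyond the scatter.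

Compound 4 (`C=C(CC)C(=O)c1ccc(OCC(=O)Nc2ccc(C#N)cc2)c(Cl)c1Cl`) differs from compound 3 in one place: cyano in place of 2-(ethoxycarbonyl)ethenyl on an aromatic carbon, para to a large group (cyano in place of 2-(ethoxycarbonyl)ethenyl on an aromatic carbon). Among the measured compounds shown here, the only measured step, an at least 5.2-fold lower number from compound 1 to compound 2 (0.71 log units; beyond the scatter), is made on an amide-type nitrogen, so it bears on this change only indirectly. That step brings in an ethoxycarbonyl, and compound 4 gives one up. Compound 4 does keep the aromatic ring of compound 3, so a modest rise to a higher number in this assay seems more likely than a fall to the limit's side.

The expected change is a 2.4-fold higher number from compound 3 to compound 4 (0.37 log units; beyond the scatter). For compound 4, the estimated value is 4000 nM, with an expected range from 1300 nM to 15000 nM.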

Compound 4, half-maximal effective concentration: 7800 nM
Estimate against measurement, compound 4: 2.0-fold (0.29 log units) below; measured number inside the range.
By their numbers in this assay, from the lowest: compound 3; then compounds 2 and 4 (each within the scatter of the next). At a limit, above all of these: compound 1.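

Swapping in cyano on this aromatic carbon, para to a large group, is not a neutral change in this assay: the result is a 4.6-fold higher number from compound 3 to compound 4 (0.66 log units; beyond the scatter), so the group at this place clearly affects the number. The amide-nitrogen comparison adds that there is a 1.6-fold higher number from compound 2 to compound 4 (0.21 log units; within the scatter), which leaves these two compounds indistinguishable despite their different groups on that nitrogen. The remaining comparison is an at least 3.2-fold lower number from compound 1 to compound 4 (0.50 log units; beyond the scatter), and it gives only a bound, as compound 1 stands at a limit: the limit of > 25000 nM in this assay, at which 1 of the 4 values shown sits.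

The ethenyl link and the ethoxycarbonyl leave together in this one step, so which part accounts for the difference remains open. A carboxylic acid at the end of the ethenyl chain, or an amine on that aromatic carbon, would test different parts of this question.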